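Methyl for Methoxy on a Thiazole Hydrazide Series

The compounds below may be only part of what the source reports. "The series", "measured", "known", "first", "only" and "open" are said of these compounds alone.

Three compounds sharing one core are compared here. Compound 1 `O=C(CSc1nnnn1-c1ccccc1)N/N=c1/scc(-c2ccc(Br)cc2)n1-c1ccccc1` carries a bromine on its outer six-membered ring and was tested in a functional assay on C6 cells (Rattus norvegicus) for cytotoxicity, read by MTT assay, with a stated time of 24 h (on this read-out lower numbers stand for stronger inhibition and higher numbers for weaker inhibition), where compound 1 gives 21 ug/mL. Within the data shown here, compound 2 `COc1ccc(-c2cs/c(=N/NC(=O)CSc3nnnn3-c3ccccc3)n2-c2ccccc2)cc1` carries a methoxy group in the same region; in this assay compound 2 gives "not determined" (no result reported), so nothing can be said about where compound 2 stands on this read-out, and no step from compound 2 to any other compound can be drawn.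

Compound 3 `Cc1ccc(-c2cs/c(=N/NC(=O)CSc3nnnn3-c3ccccc3)n2-c2ccccc2)cc1` is the next compound. The change from compound 2 to compound 3 is methyl in place of methoxy on an aromatic carbon. Among the measured compounds shown here, with no measured step for this change, its expected size can only be guessed: a move of this kind is expected to stay within the usual scatter of this assay, with no clear direction, because the only available anchor is compound 1 at 21 ug/mL, a close relative with a different group at the same position.

Compound 3 is therefore expected to give about 22 ug/mL in this assay, with a plausible range from 9 ug/mL to 55 ug/mL.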

Compound 3, half-maximal inhibitory concentration: 14.7 ug/mL
The estimate for compound 3 lay 1.5-fold (0.18 log units) above the measured number; the measured number falls inside the stated range.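

In this assay, among these compounds, methyl in place of bromo on an aromatic carbon gives a 1.4-fold lower number from compound 1 to compound 3 (0.15 log units; within the scatter) and so provides the first comparison at this position: the read-out does not separate these two groups, even though they are different kinds of substituent, one a halogen and the other a small carbon group. The step from methoxy to methyl, which is the change actually made between compound 2 and compound 3, cannot be read, as compound 2 has no result, so this change itself remains without a measured size or direction. Nothing measured here offers an explanation for how the bromo and methyl compounds compare.

Among the compounds shown here, the two readable compounds show only that one exchange at this position stays within the scatter, which is too little to call the position insensitive to change in general. Still open, on these data alone, is whether a group of a different kind in the same place, such as an amine, a carboxylic acid or a longer chain, would give a number that can be told apart from those of compound 1 and compound 3.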